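This account rests on a few compounds, and the source may have more. Where it says the series, first, only, none or still open, it means among the compounds named here.

Of the compounds shown here, three sharing one core have been tested in a functional assay on the whole organism (artery, strain albino) with Rattus norvegicus as the target, with a stated time of 360 min, at a dose of 10 mg/kg by the oral route; a higher number here means more inhibition at the dose given (going by the name of the read-out), a lower number less inhibition. Compound 1 `COc1ccc(C2N=C(SCc3ccc(F)cc3)NC(C)=C2C(=O)Nc2ccc(F)cc2)cc1OC` gives 37.1%. Compound 2 `CC1=C(C(=O)Nc2ccc(Br)cc2)C(c2ccc(Cl)cc2Cl)N=C(SCc2ccccc2)N1` gives 24.2%. Compound 3 `CC1=C(C(=O)Nc2ccc(Br)cc2)C(c2ccc(Cl)cc2Cl)N=C(SCc2ccccc2Cl)N1` gives 38.1%, the largest number of the three, although the gap to compound 1 lies within the scatter, so the two cannot be told apart; only compound 2 sits clearly lower.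

One measured step speaks to compound 3: chloro in place of hydrogen on an aromatic carbon raised the read-out by a number 13.9 percentage points higher from compound 2 to compound 3 (beyond the scatter), a modest gain that is beyond the scatter.

Compound 4 `CC1=C(C(=O)Nc2ccc(Br)cc2)C(c2ccc(Cl)cc2Cl)N=C(SCc2cccc(Cl)c2)N1` has the same atoms as compound 3, joined differently: 3-chlorophenyl in place of 2-chlorophenyl on a saturated chain carbon bound to a sulfur. Within the data shown here, no measured pair shows what moving the chlorine from one place to another on this ring does; the only step seen concerns adding the chlorine, not shifting it. With nothing to point either way, no change beyond the scatter is expected in this assay, and the step from compound 3 is estimated at a number 2.1 percentage points lower from compound 3 to compound 4 (within the scatter). Compound 4 is therefore expected to give about 36%, with a likely range from 22% to 50%.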

Compound 4, a percentage reported as inhibition, in the whole organism at one dose (the size of the read-out at that dose, not a potency): 20.6%
Compound 4: middle estimate off by 15.4 percentage points, on the high side, and the stated range ends above it.
By their numbers in this assay, from the lowest: compounds 4 and 2 (each within the scatter of the next); then compounds 1 and 3 (each within the scatter of the next).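

On this ring the position of the chlorine matters, not only its presence: in this assay, 3-chlorophenyl in place of 2-chlorophenyl on a saturated chain carbon bound to a sulfur gives a number 17.5 percentage points lower from compound 3 to compound 4 (beyond the scatter). Adding a chloro to the plain ring of compound 2 therefore does not help in every case: the 3-chlorophenyl form gives only a number 3.6 percentage points lower from compound 2 to compound 4 (within the scatter), so it cannot be told apart from the compound without chlorine, whereas the 2-chlorophenyl form gave a number 13.9 percentage points higher from compound 2 to compound 3 (beyond the scatter). Nothing measured here explains why the two placements of the chlorine differ.

Still open, going by these compounds, is whether the gain belongs to chlorine itself or would also appear with a bromine or a methyl group in the place that chlorine holds in 2-chlorophenyl, and whether a longer chain carrying the ring on the sulfur would keep it. All of these numbers also come from a single oral dose, so they leave open how the compounds would rank across a range of doses.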